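A Carboxyethyl Group Replaces the Carbamoyl of Compound 3

A few compounds are considered here, and "the series" means these few. Any claim that something is new, unique, unknown or untested is made for them only; others in the source may bear on it.

Three compounds have been measured in a functional assay (Oryctolagus cuniculus) for antagonist activity at platelet-activating factor receptor (Cavia porcellus); a lower number here means a stronger inhibitor, a higher number a weaker inhibitor:

Compound 1 `CN(C)C(=O)n1cc(C(=O)c2ccn3c2CSC3c2cccnc2)c2ccccc21`: 95 nM
Compound 2 `CN(C)C(=O)n1cc(C(=O)c2ccn3c2CSC3c2cccnc2)c2ccc(Cl)cc21`: 89 nM
Compound 3 `CCNC(=O)n1cc(C(=O)c2ccn3c2CSC3c2cccnc2)c2ccc(-c3ccc(F)cc3)cc21`: 19 nM

Compound 3 gives the lowest number of the three, and its distance from compound 1 and from compound 2 lies beyond the scatter. Compound 4 `O=C(O)CCn1cc(C(=O)c2ccn3c2CSC3c2cccnc2)c2ccc(-c3ccc(F)cc3)cc21` differs from compound 3 in one place: 2-carboxyethyl in place of ethylcarbamoyl on an aromatic nitrogen. Among the measured compounds shown here, the single measured step, a 1.1-fold lower number from compound 1 to compound 2 (0.03 log units; within the scatter), concerns a substituent on an aromatic carbon and does not touch the group on the aromatic nitrogen, so no measured step bears on this change. With nothing to anchor the direction, a modest rise in the number is expected, within roughly a 2.1-fold higher number from compound 3 to compound 4 (0.32 log units; beyond the scatter). Compound 4 is therefore estimated at 40 nM, with a range from 10 nM to 160 nM.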

Compound 4, inhibition constant: 160 nM
Compound 4: the middle estimate sits 4.0-fold (0.60 log units) below what was measured, within the range that was stated.
By their numbers in this assay, from the lowest: compound 3; then compounds 2, 1 and 4 (each within the scatter of the next).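

Among the compounds shown here, on the aromatic nitrogen, the group is not interchangeable in this assay: 2-carboxyethyl in place of ethylcarbamoyl gives an 8.4-fold higher number from compound 3 to compound 4 (0.93 log units; beyond the scatter), the first measured step at this position. The entering and leaving groups have equal counts of heavy atoms, hydrogen-bond donors and hydrogen-bond acceptors, so these counts do not separate the two compounds. No available evidence accounts for this step.

From the compounds shown here alone, it remains open how a longer chain ending in a carboxylic acid would compare with the 2-carboxyethyl group. Going by these compounds, the effect of an amine at the end of the chain on the same nitrogen also remains open.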